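This account rests on a few compounds, and the source may have more. Where it says the series, first, only, none or still open, it means among the compounds named here.

Working notes on the series. In a functional assay on BGC-823 cells (Homo sapiens) for cytotoxicity, read by MTT assay (on this read-out lower numbers stand for stronger inhibition and higher numbers for weaker inhibition), compound 1 `COc1ccc(/C=C/C(=O)c2sc(Nc3ccc(Cl)cc3)nc2C)cc1` gives > 25000 nM, which is a limit of the assay and not a number. Compound 2 `COc1cc(/C=C/C(=O)c2sc(Nc3ccc(Cl)cc3)nc2C)cc(OC)c1OC` gives > 25000 nM in this assay, again a limit rather than a number. Compound 3 `Cc1nc(Nc2cccc(Cl)c2)sc1C(=O)/C=C/c1ccc(Cl)cc1` likewise gives > 25000 nM in this assay, also a limit. Within the data shown here, compound 2 therefore stands where every measured compound of the series stands, at the limit, since (the limit of > 25000 nM in this assay, at which 3 of the 3 values shown sit); no step between measured compounds can be read from these numbers, and nothing separates compound 2 from compound 1 or compound 3 beyond the fact that each is a limit.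

Compound 4 `COc1cc(/C=C/C(=O)c2sc(Nc3ccc(F)c(Cl)c3)nc2C)cc(OC)c1OC` differs from compound 2 by 3-chloro-4-fluorophenyl in place of 4-chlorophenyl on a nitrogen on an aromatic ring; the rest of the structure, with its three methoxy groups on the styryl ring and the shared core, is unchanged. Among the measured compounds shown here, with only limits measured, no direction for this step is supported by the numbers, and the expectation is no change beyond the scatter: compound 4 is expected to remain at or beyond the limit, estimated as 40000 nM in this assay, with a range from 15000 nM to 150000 nM. The step from compound 2 to compound 4 is thus estimated as a step that the limit leaves unreadable from compound 2 to compound 4.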

Compound 4, half-maximal inhibitory concentration: 9700 nM
The estimate for compound 4 lay 4.1-fold (0.62 log units) above the measured number; measured number outside the range, below it.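

In this assay, among these compounds, the change to 3-chloro-4-fluorophenyl in place of 4-chlorophenyl on a nitrogen on an aromatic ring gives an at least 2.5-fold lower number from compound 2 to compound 4 (0.41 log units; beyond the scatter), so the series responds to a change at this position, which the earlier compounds could not show. Among the compounds shown here, compound 4 is the first compound here to give a number rather than a limit, and the true size of the step stays bounded on one side only, since the value of compound 2 is a limit. No other step can be read, and the remaining values offer no comparison: the limit of > 25000 nM in this assay, at which 3 of the 4 values shown sit.

Going by these compounds, whether the step comes from the added fluorine or from chlorine standing at the 3-position rather than the 4-position remains open. On these data alone, how a methoxy group, a trifluoromethyl group or a carboxylic acid on this aromatic ring would read is also open.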